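This account rests on a few compounds, and the source may have more. Where it says the series, first, only, none or still open, it means among the compounds named here.

Measured in an assay on cells for displacement of a labelled ligand from prostaglandin E2 receptor EP4 subtype (Homo sapiens), read by scintillation counting; a higher number here means a weaker inhibitor, a lower number a stronger inhibitor:
compound 1, `Cc1oc(C(=O)O)cc1COc1ccc(-c2ccc(OC(F)(F)F)cc2)cc1`: 2400 nM
compound 2, `Cc1oc(C(=O)O)cc1COc1ccc(-c2ccc(S(C)(=O)=O)cc2)cc1`: a limit of the assay, > 10000 nM
compound 3, `Cc1oc(C(=O)O)cc1COc1ccc(-c2ccc(Cl)cc2)cc1`: 1000 nM

Compound 3 holds the lowest of the two numbers in this assay; compound 1 stands nearest, and the step between them is a 2.4-fold lower number from compound 1 to compound 3 (0.38 log units; beyond the scatter). Compound 2 sits at the limit of > 10000 nM in this assay, at which 1 of the 3 values shown sits.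

Compound 4, `CC(=O)c1ccc(-c2ccc(OCc3cc(C(=O)O)oc3C)cc2)cc1`, has not been measured. It differs from compound 3 in one place: acetyl in place of chloro on an aromatic carbon. Among the measured compounds shown here, three measured steps concern substituents at this same aromatic carbon: a 2.4-fold lower number from compound 1 to compound 3 (0.38 log units; beyond the scatter), an at least 10-fold lower number from compound 2 to compound 3 (1.00 log units; beyond the scatter) and an at least 4.1-fold higher number from compound 1 to compound 2 (0.61 log units; beyond the scatter). Chloro gave the lowest number, trifluoromethoxy a modestly higher one, and methylsulfonyl a number beyond the upper limit of the assay. Acetyl is a third group replacing chloro, so compound 4 is expected to give a higher number than compound 3, the step of a 4.0-fold higher number from compound 3 to compound 4 (0.60 log units; beyond the scatter) being the estimate. Compound 4 is therefore estimated at 4000 nM in this assay, with a range from 1500 nM to 12000 nM.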

Compound 4, inhibition constant: 150 nM
Compound 4: the middle estimate sits 27-fold (1.43 log units) above what was measured; measured number below the stated range.
By their numbers in this assay, from the lowest: compound 4; then compound 3; then compound 1. At a limit, above all of these: compound 2.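

In this assay, acetyl is the first group at this aromatic carbon to go below chloro, a 6.7-fold lower number from compound 3 to compound 4 (0.82 log units; beyond the scatter), so chloro no longer holds the lowest number among these substituents. Acetyl also stands well clear of trifluoromethoxy, a 16-fold lower number from compound 1 to compound 4 (1.20 log units; beyond the scatter), a wider step than any measured earlier between two exact values at this carbon. The exchange of methylsulfonyl for acetyl is wider still, an at least 66-fold lower number from compound 2 to compound 4 (1.82 log units; beyond the scatter), and its size is only a bound, resting on a limit and not a number: the limit of > 10000 nM in this assay, at which 1 of the 4 values shown sits.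

The compounds shown leave open whether the lower number belongs to the carbonyl alone or to the whole acetyl group. An amide, a methyl ester or a longer ketone chain at this carbon would help to separate the two.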